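The source may report more compounds than this note shows. Statements on the series, on what has been measured and on what is new or still open speak of the compounds shown alone.

Measured in a functional assay on PC-3 cells (Homo sapiens) for cytotoxicity, read by MTT assay, with a stated time of 72 h; a higher number here means a weaker inhibitor, a lower number a stronger inhibitor:
- compound 1 `CNC(=O)c1cc(Oc2ccc(C3=NNC(c4cccc(Br)c4)C3)cc2)ccn1`: 3540 nM
- compound 2 `CNC(=O)c1cc(Oc2ccc(C3=NNC(c4ccccc4)C3)cc2)ccn1`: 4520 nM

For the measured compounds named here, compound 2 lies within the scatter of compound 1, the only other measured compound. Next is compound 3 `CNC(=O)c1cc(Oc2ccc(C3=NNC(c4ccc(Cl)c(Cl)c4)C3)cc2)ccn1`, with 3,4-dichlorophenyl in place of phenyl on a saturated ring carbon. Going by the values given here, only one measured step bears on this, a 1.3-fold higher number from compound 1 to compound 2 (0.11 log units; within the scatter), hydrogen in place of bromo on an aromatic carbon, and it stays within the scatter. On that evidence, no shift beyond the scatter is expected in this assay. Compound 3 is estimated at 3300 nM, with an expected range of 1300 nM to 8000 nM. The expected step is a 1.4-fold lower number from compound 2 to compound 3 (0.14 log units; within the scatter).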

Compound 3, half-maximal inhibitory concentration: 36200 nM
Estimate against measurement, compound 3: 11-fold (1.04 log units) below; measured number above the stated range.
By their numbers in this assay, from the lowest: compounds 1 and 2 (each within the scatter of the next); then compound 3.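

In this assay the aryl group on the saturated ring carbon proves able to move the number beyond the scatter: 3,4-dichlorophenyl in place of phenyl gives an 8.0-fold higher number from compound 2 to compound 3 (0.90 log units; beyond the scatter) and 3,4-dichlorophenyl in place of 3-bromophenyl gives a 10-fold higher number from compound 1 to compound 3 (1.01 log units; beyond the scatter) while the earlier loss of bromo stayed within the scatter. No measurement here gives a reason for this shift. Open, on these data alone, is whether a single chlorine carries the shift, and how an amine or a carboxylic acid on that phenyl ring would read.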